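The compounds below may be only part of what the source reports. "The series", "measured", "known", "first", "only" and "open" are said of these compounds alone.

Measured so far:
compound 1 `COc1ccc(-n2c(SCc3ccc(C)cc3)nnc2-c2cc(OC)c(OC)c(OC)c2)cc1` — 56500 nM
compound 2 `COc1ccc(CSc2nnc(-c3cc(OC)c(OC)c(OC)c3)n2-c2ccc(OC)cc2)cc1` — 40300 nM
compound 3 `COc1ccc(-n2c(SCC(=O)c3ccc4ccccc4c3)nnc2-c2cc(OC)c(OC)c(OC)c2)cc1` — a limit of the assay, > 60000 nM

In a functional assay on PC-3 cells (Homo sapiens) for inhibition, read by MTT assay, with a stated time of 48 h (on this read-out lower numbers stand for stronger inhibition and higher numbers for weaker inhibition), compound 2 gives 40300 nM, the lowest of the two numbers available, with compound 1 nearest at 56500 nM. The step of a 1.4-fold lower number from compound 1 to compound 2 (0.15 log units; within the scatter) is within the scatter, so the two cannot be ranked. Compound 3 reaches only a limit of this assay, > 60000 nM, a point at which one of the three values sits (the limit of > 60000 nM in this assay, at which 1 of the 3 values shown sits).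

Compound 4 `CCOC(=O)CSc1nnc(-c2cc(OC)c(OC)c(OC)c2)n1-c1ccc(OC)cc1` has not yet been measured. It differs from compound 2 at the same position where compounds 1 and 3 diverge from it: ethoxycarbonyl in place of 4-methoxyphenyl on a saturated chain carbon bound to a sulfur.

For the measured compounds named here, two measured steps bear on this change, both made on the saturated chain carbon bound to a sulfur. The step of an at least 1.4-fold higher number from compound 2 to compound 3 (0.17 log units; that floor lies within the scatter) and the step of an at least 1.0-fold higher number from compound 1 to compound 3 (0.02 log units; that floor lies within the scatter) each end at the limit, and each floor lies within the scatter. Exchanging the group at this place has therefore not produced a step beyond the scatter in either direction so far.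

For compound 4 no step beyond the scatter is expected in this assay, with the outcome possibly again sitting at the limit. Compound 4 is estimated at 55000 nM, in the range 25000 nM to 120000 nM. The expected step is a 1.4-fold higher number from compound 2 to compound 4 (0.14 log units; within the scatter).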

Compound 4, half-maximal inhibitory concentration: > 60000 nM
Compound 4: no number, only a limit; the forecaster's own chance of this, stated with the estimate: 40%; at least 1.0-fold (0.03 log units) between middle value and limit.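

In this assay compound 4 gives > 60000 nM, which is a limit of the assay and not a number, and it shares that limit with compound 3, so an ethoxycarbonyl group without any ring ends at the same point as the (naphthalen-2-yl)carbonyl group: the limit of > 60000 nM in this assay, at which 2 of the 4 values shown sit.

The two readable steps are an at least 1.4-fold higher number from compound 2 to compound 4 (0.17 log units; that floor lies within the scatter) and an at least 1.0-fold higher number from compound 1 to compound 4 (0.02 log units; that floor lies within the scatter); they extend the earlier picture to a group with no ring, and still no step at this saturated chain carbon bound to a sulfur is shown beyond the scatter, although both are only floors and a larger true step is not excluded. The remaining step, between compound 3 and compound 4, cannot be read, since both ends are limits.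

On these data alone, what remains open is whether any group at this place can give a number clearly lower than those of compound 1 and compound 2. As far as these compounds go, a carboxylic acid, an amine or a longer chain on this saturated chain carbon bound to a sulfur would test that, and the true numbers of compound 3 and compound 4 also remain unknown.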